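This account rests on a few compounds, and the source may have more. Where it says the series, first, only, none or still open, it means among the compounds named here.

Notes on the series. In a functional assay on RS4-11 cells (Homo sapiens) for inhibition, read by CCK-8 assay, with a stated time of 48 h, tested at 20 uM (a higher number here means more inhibition of growth at the concentration tested, a lower number less inhibition of growth), compound 1 `Cc1ccc(S(=O)(=O)Oc2ccccc2/C=C(\C#N)C(=O)Nc2nnc(Cc3ccccc3)s2)cc1` gives 69%. Among the compounds with values here, compound 2 `N#C/C(=C\c1ccccc1OS(=O)(=O)c1ccccc1[N+](=O)[O-])C(=O)Nc1nnc(Cc2ccccc2)s1` gives 71%, which leaves it level with the only other measured member. The gap is a number 2 percentage points higher from compound 1 to compound 2 (within the scatter).

Compound 3 `N#C/C(=C\c1ccccc1OS(=O)(=O)c1ccc(Cl)cc1)C(=O)Nc1nnc(Cc2ccccc2)s1` keeps the shared core and has 4-chlorophenyl in place of 2-nitrophenyl on a sulfonyl sulfur.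

Within the data shown here, only one measured step bears on this change, the earlier exchange of the group on the same sulfonyl sulfur, which gave a number 2 percentage points higher from compound 1 to compound 2 (within the scatter). Among the measured compounds shown here, that is a single step, and no member carrying 4-chlorophenyl has been measured, so the basis is thin. No step beyond the scatter is expected in this assay.

The expected step is a number 1 percentage points lower from compound 2 to compound 3 (within the scatter).

For compound 3 the estimated value is 70%, with an expected range of 56% to 84%.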

Compound 3, percent growth inhibition at one concentration: 73%
Compound 3: the middle estimate sits 3 percentage points below what was measured, within the range that was stated.
By their numbers in this assay, from the lowest: compounds 1, 2 and 3 (each within the scatter of the next).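

In this assay, the exchange of 2-nitrophenyl for 4-chlorophenyl on the sulfonyl sulfur gives a number 2 percentage points higher from compound 2 to compound 3 (within the scatter), so a third aromatic group at this position stays level with the other two. Chloro in place of methyl on an aromatic carbon gives a number 4 percentage points higher from compound 1 to compound 3 (within the scatter), which adds a direct comparison of these two substituents and likewise separates nothing, so across compounds 1, 2 and 3 the choice among these groups makes no readable difference. Nothing available explains why these numbers stay together.

Still open, going by these compounds, is whether an amine or a carboxylic acid on this aromatic ring, or a butyl chain in place of the ring on the sulfonyl sulfur, would move the number beyond the scatter. A read-out at one concentration also leaves open whether these compounds would stay level at other concentrations.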